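Methoxy to Ethoxy: A Small Step on a Shared Core

This account rests on a few compounds, and the source may have more. Where it says the series, first, only, none or still open, it means among the compounds named here.

Of the compounds shown here, three have so far been measured in a functional assay on NCI-H3255 cells (Homo sapiens) for antiproliferative activity, read by MTT assay, with a stated time of 72 h; on this read-out higher numbers stand for weaker inhibition and lower numbers for stronger inhibition. Compound 1 `COc1cccc(Nc2cc(Nc3cc(OC)ccc3OC)ncn2)c1` gives 860 nM. Compound 2 `CCOC(=O)CCCC(=O)Nc1cc(Nc2cccc(Cl)c2)ncn1` is reported only as a limit of the assay, > 30000 nM. Compound 3 `COc1ccc(Nc2cc(NC(=O)c3ccccc3)ncn2)cc1` gives 8880 nM, the higher of the two numbers reported; its nearest neighbour is compound 1, whose number is lower by a gap that lies beyond the usual scatter.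

Compound 4 `CCOc1ccc(Nc2cc(NC(=O)c3ccccc3)ncn2)cc1` has not yet been measured. It differs from compound 3 in one place: methyl in place of hydrogen on a saturated chain carbon bound to an oxygen on an aromatic ring. Going by the values given here, no pair of measured compounds differs by a single change, so no measured step shows how a change of this kind acts on this core. The change itself is small, adding one carbon to a chain on the outer edge of the molecule. The step of a 1.1-fold lower number from compound 3 to compound 4 (0.05 log units; within the scatter) is therefore expected to stay within the scatter, in no clear direction. Compound 4 is expected to give about 8000 nM, with a likely range from 3000 nM to 25000 nM.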

Compound 4, half-maximal inhibitory concentration: 9170 nM
For compound 4 the middle estimate is 1.1-fold (0.06 log units) below the measured one; the measured number falls inside the stated range.
By their numbers in this assay, from the lowest: compound 1; then compounds 3 and 4 (each within the scatter of the next). At a limit, above all of these: compound 2.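

Going by these compounds alone, this is the first step measured between two compounds that differ in one place, and in this assay it reads a 1.0-fold higher number from compound 3 to compound 4 (0.01 log units; within the scatter) and so gives the methoxy to ethoxy change a direct measurement for the first time. With a methyl in place of hydrogen on a saturated chain carbon bound to an oxygen on an aromatic ring, the two numbers cannot be told apart, so on this core the position takes one extra carbon without a measurable difference in this read-out. Within the data shown here, nothing measured so far explains why the step is so small.

The compounds shown leave open whether a longer chain, an amine or a carboxylic acid in place of the ethoxy would also leave the number within the scatter. They also leave open whether the same step would read alike on another core.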